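Benzyloxy for iodo on the shared core of the series

A few compounds are considered here, and "the series" means these few. Any claim that something is new, unique, unknown or untested is made for them only; others in the source may bear on it.

In a toxicity assay on WI-38 cells (Homo sapiens) for cytotoxicity, read by MTT assay, with a stated time of 48 h (on this read-out higher numbers stand for weaker inhibition and lower numbers for stronger inhibition), compound 1 `O=C(/C=C/c1ccc2c(c1)B(O)OC2)c1ccccc1` gives 19100 nM. Compound 2 `O=C(/C=C/c1ccc2c(c1)B(O)OC2)c1ccc(Cl)cc1` gives 24700 nM in this assay, a change of a 1.3-fold higher number from compound 1 to compound 2 (0.11 log units; within the scatter). For compound 3 `O=C(/C=C/c1ccc2c(c1)B(O)OC2)c1ccc(I)cc1` this assay reports only a limit, > 100000 nM. Compound 3 therefore sits at the top end of the numbers shown, at the limit of > 100000 nM in this assay, at which 1 of the 3 values shown sits, and the steps of an at least 5.2-fold higher number from compound 1 to compound 3 (0.71 log units; beyond the scatter) and an at least 4.0-fold higher number from compound 2 to compound 3 (0.60 log units; beyond the scatter) are both beyond the scatter, so compound 3 is the weakest inhibitor of the three.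

Compound 4 `O=C(/C=C/c1ccc2c(c1)B(O)OC2)c1ccc(OCc2ccccc2)cc1` carries the change (benzyloxy in place of iodo on an aromatic carbon). Among the measured compounds shown here, no measured step introduces benzyloxy; the two steps that reach compound 3 only end at a limit and show that iodo gave a higher number than hydrogen or chloro at this carbon. The expected step in this assay, an at least 1.6-fold lower number from compound 3 to compound 4 (0.22 log units; that floor lies within the scatter), is thus set mainly by the wide spread of the three measured values. Compound 4 is estimated at 60000 nM, within a range of 20000 nM to 150000 nM, with a real chance that only a limit is reported.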

Compound 4, half-maximal inhibitory concentration: > 100000 nM
Compound 4: a limit, no number; the forecaster's own chance of this, stated with the estimate: 40%; at least 1.6-fold (0.22 log units) between middle value and limit.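

Compound 4 also ends at a limit in this assay, so benzyloxy, with its added six-membered aromatic ring of carbon only, joins iodo at the top end of the series: the limit of > 100000 nM in this assay, at which 2 of the 4 values shown sit.

The steps of an at least 4.0-fold higher number from compound 2 to compound 4 (0.60 log units; beyond the scatter) and an at least 5.2-fold higher number from compound 1 to compound 4 (0.71 log units; beyond the scatter) show that a higher number at this aromatic carbon is not confined to iodo, while chloro stays within the scatter of hydrogen. Compound 3 and compound 4 are both limits, and the step between them cannot be read.

From the compounds shown here alone, whether iodo and benzyloxy differ at all in this assay stays open. Also open, going by these compounds, is whether an amine or a carboxylic acid at this carbon would give a number in the range of compound 1 and compound 2 or also end at a limit.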